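Trimming the piperidine nitrogen substituent toward a methyl

The compounds below may be only part of what the source reports. "The series", "measured", "known", "first", "only" and "open" are said of these compounds alone.

Compound 1 `Cc1ccc2c(NCc3ccc(NC(=O)C4CCN(C(=O)OC(C)(C)C)CC4)cc3)nc(N(C)C)nc2c1` carries a tert-butoxycarbonyl on the ring nitrogen; in a functional assay on SV5A8 cells (Homo sapiens) for cytotoxicity (on this read-out lower numbers stand for stronger inhibition and higher numbers for weaker inhibition), compound 1 reaches only the limit > 4820 nM. Compound 2 `Cc1ccc2c(NCc3ccc(NC(=O)C4CCN(CC(C)C)CC4)cc3)nc(N(C)C)nc2c1` likewise gives only the limit > 10500 nM in this assay. The step that the two limits leave unreadable from compound 1 to compound 2 therefore cannot be sized. Compound 3 `Cc1ccc2c(NCc3ccc(NC(=O)C4CCN(C)CC4)cc3)nc(N(C)C)nc2c1` differs from compound 2 by hydrogen in place of isopropyl on a saturated chain carbon bound to an amine nitrogen in a ring. Among the measured compounds shown here, with both neighbours sitting at limits, no measured step sets a direction for this assay, so compound 3 is expected to remain near the limit, with an estimated step that the limit leaves unreadable from compound 2 to compound 3. Compound 3 is estimated at 15000 nM, between 3000 nM and 80000 nM.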

Compound 3, half-maximal inhibitory concentration: > 17300 nM
Compound 3: no number, only a limit; the forecaster's own chance of this, stated with the estimate: 85%; at least 1.1-fold (0.06 log units) between middle value and limit.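

Among the compounds shown here, compound 1, compound 2 and compound 3 each give only a limit in this assay, so no step among them can be read. The compounds shown leave open whether any substituent on the ring nitrogen gives a measurable value in this assay.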